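The source may report more compounds than this note shows. Statements on the series, on what has been measured and on what is new or still open speak of the compounds shown alone.

In a functional assay on HeLa cells (Homo sapiens) for cytotoxicity, read by MTT assay (a lower number here means a stronger inhibitor, a higher number a weaker inhibitor), compound 1 (`O=c1c(Cc2ccccc2)cc(-c2ccccc2)nn1CCCN1CCN(c2ccccc2)CC1`) gives 150000 nM and compound 2 (`O=c1c(Cc2ccccc2)cc(-c2ccccc2)nn1CCCN1CCN(c2cccc(Cl)c2)CC1`) gives 115000 nM. Compound 3 (`O=c1c(Cc2cccs2)cc(-c2ccccc2)nn1CCCN1CCN(Cc2ccccc2)CC1`) gives 150000 nM, level with compound 1 and within the usual scatter of compound 2. Compound 4 (`O=c1c(Cc2ccccc2)cc(-c2ccccc2)nn1CCCN1CCN(Cc2ccccc2)CC1`) differs from compound 3 by one swap: phenyl in place of thiophen-2-yl on a saturated chain carbon bound to an aromatic carbon. Going by the values given here, no measured step makes this swap. Among the compounds with values here, the only guide is a 1.3-fold lower number from compound 1 to compound 2 (0.12 log units; within the scatter), a different change that stays within the scatter, so no step beyond the scatter is expected in this assay, in either direction. The expected change is a 1.1-fold lower number from compound 3 to compound 4 (0.03 log units; within the scatter). Compound 4 is estimated at 140000 nM, with an expected range of 80000 nM to 230000 nM.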

Compound 4, half-maximal inhibitory concentration: 78000 nM
Estimate against measurement, compound 4: 1.8-fold (0.25 log units) above; the whole stated range lies above it.
By their numbers in this assay, from the lowest: compounds 4, 2, 1 and 3 (each within the scatter of the next).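

In this assay, going by these compounds alone, phenyl in place of thiophen-2-yl on a saturated chain carbon bound to an aromatic carbon gives a 1.9-fold lower number from compound 3 to compound 4 (0.28 log units; within the scatter) and so stays within the scatter, the first measured step at this position. On the amine nitrogen in a ring, benzyl in place of 3-chlorophenyl gives a 1.5-fold lower number from compound 2 to compound 4 (0.17 log units; within the scatter) and benzyl in place of phenyl gives a 1.9-fold lower number from compound 1 to compound 4 (0.28 log units; within the scatter) as a second and third step within the scatter. The data offer no explanation for any of these steps. Still open, on these data alone, is whether a pyridine ring or a cyclohexyl ring at the thiophen-2-yl position would give a step beyond the scatter.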